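A few compounds are considered here, and "the series" means these few. Any claim that something is new, unique, unknown or untested is made for them only; others in the source may bear on it.

Working notes on a small set of anilinopyrimidine benzothiazole amines assayed in a functional assay on HCT-116 cells (Homo sapiens) for antiproliferative activity, read by MTT assay, with a stated time of 48 h; on this read-out lower numbers stand for stronger inhibition and higher numbers for weaker inhibition. Compound 1 `NS(=O)(=O)c1ccc(Nc2ncc(F)c(Nc3nc4ccccc4s3)n2)cc1` gives 3260 nM in this assay. Compound 2 `Cc1cnc(Nc2ccc([N+](=O)[O-])cc2)nc1Nc1nc2ccccc2s1` gives 6330 nM, and compound 3 `CS(=O)(=O)c1ccc(Nc2nccc(Nc3nc4ccccc4s3)n2)cc1` gives 8370 nM. Compound 2 stands with the other two numbers rather than apart from them: its value differs from that of compound 3 and from that of compound 1 by less than the usual scatter of this assay, so the three measurements cannot be told apart, and no one of them is called more or less potent than another.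

Compound 4 `Cc1cnc(Nc2cccc(F)c2)nc1Nc1nc2ccccc2s1` has not been measured in this assay. Its structure differs from that of compound 2 in one place: 3-fluorophenyl in place of 4-nitrophenyl on a nitrogen on an aromatic ring. For the measured compounds named here, no pair of measured compounds differs by this same change, so no measured step can guide the expectation directly; what is known is only that the three measured compounds, carrying different groups on that nitrogen, all fall within the scatter of one another. On that basis no step beyond the scatter is expected in either direction, and the estimated step is a 1.1-fold higher number from compound 2 to compound 4 (0.04 log units; within the scatter). Compound 4 is therefore estimated at 7000 nM in this assay, with a range from 2500 nM to 20000 nM.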

Compound 4, half-maximal inhibitory concentration: 27800 nM
Compound 4: middle estimate off by 4.0-fold (0.60 log units), on the low side; the measured number lies above the stated range.
By their numbers in this assay, from the lowest: compounds 1, 2 and 3 (each within the scatter of the next, the first and the last beyond it); then compound 4.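

In this assay, the group on a nitrogen on an aromatic ring can move the read-out on the core of compound 2: 3-fluorophenyl in place of 4-nitrophenyl gives a 4.4-fold higher number from compound 2 to compound 4 (0.64 log units; beyond the scatter) and so a modest step beyond the scatter. The earlier compounds shown here offered no pair differing in one place, so their closeness in value could not show how this group alone acts, and this pair now gives the first direct reading, in the direction of a higher number and so of weaker inhibition. No measurement here bears on why the number rises, and the result stands as an observation only.

The change swaps the substituent and its place on the phenyl ring together, so this single pair cannot say how much of the step belongs to each; 4-fluorophenyl, 3-nitrophenyl or plain phenyl on the same nitrogen would separate the two. As far as these compounds go, whether the same change gives a similar step on the cores of compound 1 and compound 3, which carry other groups elsewhere, also remains open.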